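Swapping bromo for dimethylcarbamoyl on the shared core

The source may report more compounds than this note shows. Statements on the series, on what has been measured and on what is new or still open speak of the compounds shown alone.

Compound 1 `O=c1c2cc([N+](=O)[O-])ccc2n(CCCBr)n1Cc1ccccc1` gives 25200 nM in an ADME assay on L929 cells (Mus musculus) for cytotoxicity, read by resazurin assay, with a stated time of 48 h (on this read-out higher numbers stand for lower toxicity in this test and lower numbers for higher toxicity in this test), the lowest of the two plain numbers in this set. Compound 2 `COC(=O)Cn1c2ccc([N+](=O)[O-])cc2c(=O)n1Cc1ccccc1` gives 129000 nM in this assay, which is a 5.1-fold higher number from compound 1 to compound 2 (0.71 log units; beyond the scatter). For compound 3 `NC(=O)CCCn1c2ccc([N+](=O)[O-])cc2c(=O)n1Cc1ccccc1` the read-out in this assay is a limit of the assay, > 256000 nM. The step of an at least 10-fold higher number from compound 1 to compound 3 (1.00 log units; beyond the scatter) is the nearest guide to the change now in view, as both put a carbonyl-bearing group where bromo stood. Compound 4 `CN(C)C(=O)CCCn1c2ccc([N+](=O)[O-])cc2c(=O)n1Cc1ccccc1` differs from compound 1 in one place: dimethylcarbamoyl in place of bromo on a saturated chain carbon, three bonds along the chain from an aromatic nitrogen. Because compound 3 reached the limit (the limit of > 256000 nM in this assay, at which 1 of the 3 values shown sits), a step toward a higher number, that is lower toxicity, is expected here too. Compound 4 is expected to give about 160000 nM in this assay, between 60000 nM and 400000 nM, meaning a 6.3-fold higher number from compound 1 to compound 4 (0.80 log units; beyond the scatter).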

Compound 4, concentration lethal to 50% of the cells: > 256000 nM
Compound 4 ended at the assay's limit (the forecaster's own chance of this, stated with the estimate: 40%); middle value at least 1.6-fold (0.20 log units) from the limit.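

Dimethylcarbamoyl in place of bromo in this assay gives an at least 10-fold higher number from compound 1 to compound 4 (1.00 log units; beyond the scatter), so the rise seen with carbamoyl persists when the amide hydrogens give way to methyl groups. Against methoxycarbonyl, the result reads an at least 1.9-fold higher number from compound 2 to compound 4 (0.29 log units; that floor lies within the scatter), which leaves that comparison unsettled. The step between compound 3 and compound 4 cannot be read, as both stand at a limit of the assay: the limit of > 256000 nM in this assay, at which 2 of the 4 values shown sit.

Going by these compounds, how far beyond that limit either amide lies remains open. So does whether a carboxylic acid, an amine or a longer chain at this place would also move the read-out away from that of compound 1.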